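From a pentyl chain to an oxan-2-yl ring

The source may report more compounds than this note shows. Statements on the series, on what has been measured and on what is new or still open speak of the compounds shown alone.

Compound 1 `O=S(=O)(/C=C/c1ccc(O)c(O)c1)CCC1CCCCC1`: 9800 nM
Compound 2 `CCCCCCS(=O)(=O)/C=C/c1ccc(O)c(O)c1`: 7300 nM
Compound 3 `O=S(=O)(/C=C/c1ccc(O)c(O)c1)CCCCCCCCO`: 6700 nM

In a functional assay, read by fluorescence and spectrophotometry, with a stated time of 1 h (a lower number here means that less compound is needed, a higher number that more compound is needed for the effect), compound 2 stands within the scatter of both other compounds, so the three cannot be told apart on these numbers. Compound 4 `O=S(=O)(/C=C/c1ccc(O)c(O)c1)CC1CCCCO1` keeps the shared core and differs from compound 2 in one group: oxan-2-yl in place of pentyl on a saturated chain carbon bound to a sulfonyl sulfur.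

Among the measured compounds shown here, three measured steps bear on this change, since each alters the group on the chain: a 1.3-fold lower number from compound 1 to compound 2 (0.13 log units; within the scatter), a 1.5-fold lower number from compound 1 to compound 3 (0.17 log units; within the scatter) and a 1.1-fold lower number from compound 2 to compound 3 (0.04 log units; within the scatter). All three are small, even where butyl or 6-hydroxyhexyl took the place of cyclohexyl. For the measured compounds named here, they are only indirect guides, however, as no measured compound carries oxan-2-yl.

With compound 1, compound 2 and compound 3 this close, no shift beyond the scatter is expected in either direction. In this assay the expected step is a 1.1-fold higher number from compound 2 to compound 4 (0.04 log units; within the scatter). For compound 4 the estimated value is 8000 nM, with an expected range from 3500 nM to 18000 nM.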

Compound 4, half-maximal effective concentration: 10800 nM
For compound 4 the middle estimate is 1.4-fold (0.13 log units) below the measured one; the measured number falls inside the stated range.
By their numbers in this assay, from the lowest: compounds 3, 2, 1 and 4 (each within the scatter of the next).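

In this assay, among the compounds shown here, placing oxan-2-yl on the saturated chain carbon bound to the sulfonyl sulfur brings a ring hetero atom into this part of the series for the first time, and the number stays within the scatter on both available comparisons: pentyl gives way to oxan-2-yl with a 1.5-fold higher number from compound 2 to compound 4 (0.17 log units; within the scatter), and cyclohexylmethyl gives way to it with a 1.1-fold higher number from compound 1 to compound 4 (0.04 log units; within the scatter). So at this position, neither the open chain nor the carbon-only ring can be told apart from the oxygen-containing ring. No measurement here explains why these numbers stay so close.

Cyclohexylmethyl and oxan-2-yl differ in more than the ring oxygen, so the effect of that oxygen alone remains unknown. Going by these compounds, whether an amine or a carboxylic acid on this chain would move the number beyond the scatter also remains open.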